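This account rests on a few compounds, and the source may have more. Where it says the series, first, only, none or still open, it means among the compounds named here.

Working notes on the series, read in a functional assay on DU-145 cells (Homo sapiens) for inhibition, read by trypan blue exclusion, with a stated time of 96 h; a lower number here means a stronger inhibitor of growth, a higher number a weaker inhibitor of growth. Within the data shown here, compound 1 (`O=C(/C(=C\c1ccc(Br)cc1)SCc1ccc(F)cc1)c1ccc(Cl)cc1`) gives 9000 nM, and compound 2 (`O=C(/C(=C\c1c[nH]c2ccc(Br)cc12)SCc1ccc(F)cc1)c1ccc(Cl)cc1`) gives 50000 nM, the higher of the two numbers so far. The next structure is compound 3 (`Cc1ccsc1/C=C(/SCc1ccc(F)cc1)C(=O)c1ccc(Cl)cc1`), with the change (3-methylthiophen-2-yl in place of 5-bromo-1H-indol-3-yl on a double-bonded chain carbon bound to a double-bonded chain carbon). Among the measured compounds shown here, only one measured step bears on it: a 5.6-fold higher number from compound 1 to compound 2 (0.74 log units; beyond the scatter), a modest step made at the same place when 5-bromo-1H-indol-3-yl replaced 4-bromophenyl. Compound 3 also lacks 5-bromo-1H-indol-3-yl, so a step of similar size towards a lower number is expected in this assay. For the measured compounds named here, this expectation rests on compound 1 at 9000 nM, but no measured compound carries 3-methylthiophen-2-yl, so the range stays wide. The expected change is a 4.2-fold lower number from compound 2 to compound 3 (0.62 log units; beyond the scatter). For compound 3 the estimate is 12000 nM, with an expected range of 4000 nM to 35000 nM.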

Compound 3, concentration for 50% growth inhibition: 50000 nM
For compound 3 the middle estimate is 4.2-fold (0.62 log units) below the measured one; measured number above the stated range.
By their numbers in this assay, from the lowest: compound 1; then compounds 2 and 3 (each within the scatter of the next).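

At the double-bonded chain carbon, this assay gives no change at the digits printed from compound 2 to compound 3 (within the scatter), so replacing 5-bromo-1H-indol-3-yl does not by itself bring the number back towards that of compound 1. The comparison with 4-bromophenyl gives a 5.6-fold higher number from compound 1 to compound 3 (0.74 log units; beyond the scatter), matching in size a 5.6-fold higher number from compound 1 to compound 2 (0.74 log units; beyond the scatter), so two different groups now share a single reading and, of the three groups shown, only 4-bromophenyl gives a lower number. No measurement available offers a reason for this result.

On these data alone, it remains open whether the lower number of compound 1 depends on the bromine or on the phenyl ring itself, a question that plain phenyl or 4-chlorophenyl at this place would address. Also open, as far as these compounds go, is how an amine or a carboxylic acid on that phenyl ring would read in this assay, and whether any group here gives a number lower than that of compound 1.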